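Chloro for hydrogen on a second core: permeability notes

The source may hold more compounds than are shown below. What is called first, only, known or untested is meant among the compounds shown, and "the series" means these compounds.

Measured so far in an ADME assay for permeability, using PAMPA, at pH 5.5; a higher number here means that the compound crosses the layer faster, a lower number that the compound crosses the layer more slowly:
- compound 1, `CCCCc1nc(=O)c(S(=O)(=O)c2ccc(-n3ccccc3=O)cc2)c(O)n1-c1c(OC)cccc1OC`, gives 12 nm/s
- compound 2, `CCCCc1nc(=O)c(S(=O)(=O)c2ccc(-n3cc(Cl)ccc3=O)cc2)c(O)n1-c1c(OC)cccc1OC`, gives 83 nm/s
- compound 3, `CCCCc1[nH]c(=O)c(S(=O)(=O)c2ccc(-n3ccccc3=O)cc2)c(O)c1-c1c(OC)cccc1OC`, gives 177 nm/s

Compound 1 and compound 2 share one core and differ in a single place: chloro in place of hydrogen on an aromatic carbon. That change produced a 6.9-fold higher number from compound 1 to compound 2 (0.84 log units; beyond the scatter). Compound 3 carries a different core; the difference between the core of compound 1 and the core of compound 3 is not broken down here. Among the three numbers in this assay, compound 3 stands highest, with compound 2 nearest to it and compound 1 furthest away, both gaps lying beyond the scatter.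

Compound 4, `CCCCc1[nH]c(=O)c(S(=O)(=O)c2ccc(-n3cc(Cl)ccc3=O)cc2)c(O)c1-c1c(OC)cccc1OC`, has not yet been measured. It relates to compound 3 as compound 2 relates to compound 1: chloro in place of hydrogen on an aromatic carbon. The place is described in identical words for both pairs, so this is the same change carried onto the second core. Among the measured compounds shown here, the expectation for compound 4 rests on the single measured instance of this change, a 6.9-fold higher number from compound 1 to compound 2 (0.84 log units; beyond the scatter), and on the fact that compound 3 already gives the highest number in the set. For the measured compounds named here, only that one instance exists, and nothing shows how the second core answers to the change. The step is therefore expected to be somewhat smaller than the measured one: a 3.4-fold higher number from compound 3 to compound 4 (0.53 log units; beyond the scatter) is the expected change from compound 3 to compound 4. Compound 4 is therefore estimated at 600 nm/s, with the likely range expected to run from 250 nm/s to 1400 nm/s.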

Compound 4, apparent permeability: 285 nm/s
Compound 4: middle estimate off by 2.1-fold (0.32 log units), on the high side; the measured number falls inside the stated range.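

Working notes on carrying the change across cores: in this assay, chloro in place of hydrogen on an aromatic carbon gives a 1.6-fold higher number from compound 3 to compound 4 (0.21 log units; within the scatter), so on this core the effect of the change cannot be told apart from the usual spread of repeat measurements. The size of the step therefore did not carry over from one core to the other, and the two steps differ by more than the scatter allows: the same change on two cores in this assay, a 6.9-fold higher number (0.84 log units; beyond the scatter) from compound 1 to compound 2 and a 1.6-fold higher number (0.21 log units; within the scatter) from compound 3 to compound 4, 4.3-fold (0.63 log units) apart, beyond the scatter of two such steps

This shows that the step depends on the core for these two pairs only. With a single pair on each core, it gives no reason for the gap and no rule for any further core, and it does not establish that the change does nothing at all on the core of compound 3.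

The compounds shown hold only hydrogen and chloro at this place on the ring, so it remains open whether a fluoro group, a methyl group or an amine there would also give steps that differ between the two cores. Also open, from the compounds shown here alone, is how each core would answer to a change elsewhere in the structure, such as a longer chain in place of the butyl chain or a carboxylic acid on the outer ring.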